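Enlarging the Group on the Aromatic Carbon

A few compounds are considered here, and "the series" means these few. Any claim that something is new, unique, unknown or untested is made for them only; others in the source may bear on it.

Among the measured compounds shown here, compound 1 `CC1C(=O)N(c2ccccc2C(=O)OCC2CCCN(CCCc3ccccc3)C2)C(=O)C1C` is the weaker of the two compounds measured so far: in a functional assay with Neuronal acetylcholine receptor; alpha3/beta4 (Homo sapiens) as the target (on this read-out higher numbers stand for weaker inhibition and lower numbers for stronger inhibition), compound 1 gives 6000 nM. Compound 2 `CCCCC1CC(=O)N(c2ccccc2C(=O)OCC2CCCN(CCCc3ccccc3)C2)C1=O` differs from it at one aromatic carbon, and in this assay compound 2 gives 1500 nM; that step, a 4.0-fold lower number from compound 1 to compound 2 (0.60 log units; beyond the scatter), is the only one measured. Compound 3 `O=C(OCC1CCCN(CCCc2ccccc2)C1)c1ccccc1N1C(=O)CC(C2CCCC2)C1=O` alters compound 1 at the same aromatic carbon in a related way: a group of 12 heavy atoms (9 carbon, 1 nitrogen, 2 oxygen; one five-membered non-aromatic ring of carbon only, one five-membered non-aromatic ring with 1 hetero atom) in place of a group of 9 heavy atoms (6 carbon, 1 nitrogen, 2 oxygen; one five-membered non-aromatic ring with 1 hetero atom), on an aromatic carbon. For the measured compounds named here, the group that enters here is larger than the one in compound 1, just as in the step of a 4.0-fold lower number from compound 1 to compound 2 (0.60 log units; beyond the scatter), so a lowering of comparable size is expected in this assay, although the entering group is a ring rather than a chain, which makes the size uncertain. Compound 3 is therefore expected to give 2000 nM in this assay, a step of a 3.0-fold lower number from compound 1 to compound 3 (0.48 log units; beyond the scatter), with a range from 800 nM to 5000 nM.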

Compound 3, half-maximal inhibitory concentration: 1200 nM
Beside the measured number, compound 3's estimate is 1.7-fold (0.22 log units) above it, within the range that was stated.
By their numbers in this assay, from the lowest: compounds 3 and 2 (each within the scatter of the next); then compound 1.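

A ring of carbon now does at this position what a chain did: with the cyclopentyl group, this assay shows a 5.0-fold lower number from compound 1 to compound 3 (0.70 log units; beyond the scatter), and this step, like the one with butyl, a 4.0-fold lower number from compound 1 to compound 2 (0.60 log units; beyond the scatter), lies beyond the scatter. Cyclopentyl and butyl on the saturated ring carbon cannot be told apart here, a 1.3-fold lower number from compound 2 to compound 3 (0.10 log units; within the scatter), so in this assay the two groups read alike and both stand apart from the 3,4-dimethyl group of compound 1. Nothing available explains why these groups give lower numbers than that group.

Still open, as far as these compounds go, is whether the number would keep falling with a longer chain such as octyl or a larger ring such as cyclohexyl on that saturated ring carbon. Equally open, from the compounds shown here alone, is how an amine or a carboxylic acid in the same place would read.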